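The source may report more compounds than this note shows. Statements on the series, on what has been measured and on what is new or still open speak of the compounds shown alone.

In a functional assay on MCF7 cells (Homo sapiens) for antiproliferative activity, read by MTT assay, with a stated time of 72 h; a higher number here means a weaker inhibitor, a lower number a stronger inhibitor:

compound 1 `CNc1nc(-c2cc(OC)c(OC)c(OC)c2)c(-c2ccc(C)cc2)s1` — 10.1 nM
compound 2 `CNc1nc(-c2cc(OC)c(OC)c(OC)c2)c(-c2ccc(C(F)(F)F)cc2)s1` — 7290 nM
compound 3 `COc1cc(-c2nc(N(C)C)sc2-c2ccc(C)cc2)cc(OC)c1OC` — > 10000 nM

The value of compound 3 is a limit of the assay, not a number; compound 3 sits at the limit of > 10000 nM in this assay, at which 1 of the 3 values shown sits.

Compound 1 and compound 2 share one core and differ by trifluoromethyl in place of methyl on an aromatic carbon. In this assay this change made a large step, a 720-fold higher number from compound 1 to compound 2 (2.86 log units; beyond the scatter).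

Compound 3 carries the second core; its core differs from that of compound 1 by methyl in place of hydrogen on a nitrogen on an aromatic ring. That change gave an at least 990-fold higher number from compound 1 to compound 3 (2.99 log units; beyond the scatter), read only against the limit.

Compound 4 `COc1cc(-c2nc(N(C)C)sc2-c2ccc(C(F)(F)F)cc2)cc(OC)c1OC` is not yet measured. It differs from compound 3 by trifluoromethyl in place of methyl on an aromatic carbon, the same change as that from compound 1 to compound 2, at a place described in the same words. Beside the measured step, the expected step on the second core is a step that the limit leaves unreadable from compound 3 to compound 4; this expectation rests on compound 3 already standing at the limit of > 10000 nM in this assay, at which 1 of the 3 values shown sits, so no numerical loss can be read. For compound 4 the estimate in this assay is 40000 nM, between 10000 nM and 200000 nM, most likely reported again only as a limit.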

Compound 4, half-maximal inhibitory concentration: > 10000 nM
Compound 4 ended at the assay's limit (the forecaster's own chance of this, stated with the estimate: 90%); the middle value does not contradict the limit.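

In this assay compound 4 stands at > 10000 nM, which is a limit and not a number. Methyl in place of hydrogen on the nitrogen, carried to the trifluoromethyl compounds, gives an at least 1.3-fold higher number from compound 2 to compound 4 (0.13 log units; that floor lies within the scatter), and the step from compound 3 to compound 4 cannot be read, as both of its ends are limits. The nitrogen change therefore raises the number on the core of compound 1 beyond the scatter, but nothing shows that a step of that size carries over to the trifluoromethyl compounds, nor that it fails to carry over: the same change on two cores in this assay, an at least 990-fold higher number (2.99 log units; beyond the scatter) from compound 1 to compound 3 and an at least 1.3-fold higher number (0.13 log units; that floor lies within the scatter) from compound 2 to compound 4; the limit leaves it open whether they differ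

Going by these compounds, with compound 3 and compound 4 at the ceiling, the size of both changes on the second core stays open: the limit of > 10000 nM in this assay, at which 2 of the 4 values shown sit. Also open is how an ethyl or a longer chain on the nitrogen, or a chloro or methoxy group in place of the methyl, would read in this assay.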